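Dimethylamino in Place of Phenoxy: an Untested Analogue

This account rests on a few compounds, and the source may have more. Where it says the series, first, only, none or still open, it means among the compounds named here.

Of the compounds shown here, two sharing one core have been measured in a functional assay on LOX IMVI cells (Homo sapiens) for cytotoxicity, read by sulforhodamine B assay, with a stated time of 48 h, tested at 100 nM; a lower number here means a stronger effect, a higher number a weaker effect of the compound at the concentration tested. Compound 1 `COc1cc(C)cc(-c2c(-c3ccnc(-c4ccc(C(C)=O)cc4)c3)cnn2CC#N)c1` gives 85% in this assay. Compound 2 `Cc1cc(O)cc(-c2nn(CC#N)cc2-c2ccnc(-c3ccc(Oc4ccccc4)cc3)c2)c1` gives 103% in this assay, the higher of the two numbers; its nearest neighbour, compound 1, stands lower by a gap that lies beyond the usual scatter, so compound 2 is the weaker of the pair. For the measured compounds named here, no pair of measured compounds differs in only one place, so no single structural step has been isolated so far.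

Compound 3 `Cc1cc(O)cc(-c2nn(CC#N)cc2-c2ccnc(-c3ccc(N(C)C)cc3)c2)c1` has not yet been measured. It differs from compound 2 in one place: dimethylamino in place of phenoxy on an aromatic carbon. Going by the values given here, no measured step of this kind exists, so the size of the step in this assay cannot be read from the data. A move toward a lower number of modest size is expected, because compound 2 at 103% leaves little room for a higher reading. The expected step is a number 8 percentage points lower from compound 2 to compound 3 (within the scatter). Compound 3 is estimated at 95%, with a range from 80% to 110%.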

Compound 3, a percentage reported as activity, at one concentration (the size of the read-out at that concentration, not a potency): 101%
The estimate for compound 3 lay 6 percentage points below the measured number; the range from low to high includes it.
By their numbers in this assay, from the lowest: compound 1; then compounds 3 and 2 (each within the scatter of the next).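

At this position, on an aromatic carbon of a six-membered aromatic ring of carbon only and para to a large group, the series now has its first single-place step: dimethylamino in place of phenoxy gives a number 2 percentage points lower from compound 2 to compound 3 (within the scatter) in this assay. The exchange removes a six-membered aromatic ring of carbon only and leaves the count of hydrogen-bond acceptors as it was, yet the readings of the two compounds stay within the usual scatter of each other, so in this assay at this concentration the data do not separate phenoxy from dimethylamino. No information is available that would account for this result.

Compound 1 differs from compounds 2 and 3 in more than one place, so its reading cannot yet be assigned to any single group on the shared core. Still open, going by these compounds, is whether a carboxylic acid, a primary amine or a longer alkyl chain at this same position would give a reading beyond the scatter of those of compound 2 and compound 3, and whether a hydroxyl or methoxy group on the other aromatic ring matters on its own.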